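A few compounds are considered here, and "the series" means these few. Any claim that something is new, unique, unknown or untested is made for them only; others in the source may bear on it.

Compound 1 `O=C(/C=C/c1ccc2c(c1)B(O)OC2)c1ccc(O)cc1` and compound 2 `Nc1ccc(C(=O)/C=C/c2ccc3c(c2)B(O)OC3)cc1` share one core and differ in a single group: amino in place of hydroxy on an aromatic carbon. In a functional assay on SK-OV-3 cells (Homo sapiens) for cytotoxicity, read by MTT assay, with a stated time of 48 h (a higher number here means a weaker inhibitor, a lower number a stronger inhibitor), compound 1 gives 13000 nM, and compound 2 gives 20200 nM; the step of a 1.6-fold higher number from compound 1 to compound 2 (0.19 log units; within the scatter) stays within the scatter. Compound 3 `O=C(/C=C/c1ccc2c(c1)B(O)OC2)c1cccc(O)c1` holds the same atoms as compound 1, joined differently: 3-hydroxyphenyl in place of 4-hydroxyphenyl on a carbonyl carbon. In this assay compound 3 gives 3800 nM, and the steps of a 3.4-fold lower number from compound 1 to compound 3 (0.53 log units; beyond the scatter) and a 5.3-fold lower number from compound 2 to compound 3 (0.73 log units; beyond the scatter) both lie beyond the scatter, so compound 3 gives the lowest number of the three. Compound 4 `Nc1cccc(C(=O)/C=C/c2ccc3c(c2)B(O)OC3)c1` has not yet been measured. It differs from compound 3 as follows: amino in place of hydroxy on an aromatic carbon. Within the data shown here, this is the same kind of change as the one from compound 1 to compound 2, though not the same: there the group sits para to a large group, here meta to a large group. Because the earlier step of a 1.6-fold higher number from compound 1 to compound 2 (0.19 log units; within the scatter) stayed within the scatter, a similarly small step is expected for compound 4, namely a 1.6-fold higher number from compound 3 to compound 4 (0.20 log units; within the scatter). Compound 4 is therefore estimated at 6000 nM, with a likely range from 2500 nM to 15000 nM.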

Compound 4, half-maximal inhibitory concentration: 7400 nM
For compound 4 the middle estimate is 1.2-fold (0.09 log units) below the measured one, within the range that was stated.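

Amino in place of hydroxy gives a 1.9-fold higher number from compound 3 to compound 4 (0.29 log units; within the scatter), and in this assay this step does not differ from the earlier one, so the change carries over between these two cores: the same change on two cores in this assay, a 1.6-fold higher number (0.19 log units; within the scatter) from compound 1 to compound 2 and a 1.9-fold higher number (0.29 log units; within the scatter) from compound 3 to compound 4, 1.3-fold (0.10 log units) apart, within the scatter of two such steps

Among these compounds, both steps lie within the scatter, however, so the pairs show only that the exchange stays small here, not that it has a real effect of a fixed size, and two pairs cannot stand for other cores. The place of the group matters more clearly for amino than the exchange itself: 3-aminophenyl in place of 4-aminophenyl gives a 2.7-fold lower number from compound 2 to compound 4 (0.44 log units; beyond the scatter), while 3-aminophenyl in place of 4-hydroxyphenyl gives a 1.8-fold lower number from compound 1 to compound 4 (0.24 log units; within the scatter).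

The compounds shown leave open whether a methoxy group, a fluorine or a carboxylic acid in place of the hydroxy would also leave the number within the scatter. On these data alone, all four compounds keep the same remaining framework, so how the exchange behaves on a clearly different core also stays open.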